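The compounds below may be only part of what the source reports. "The series", "measured", "known", "first", "only" and "open" are said of these compounds alone.

Measured compounds:
Compound 1, `Nc1nc(O)c2c(n1)n(C1OC(CO)[C@@H](O)[C@H]1O)c(=O)n2C/C=C/c1ccccc1`, gives 5%.
Compound 2, `C=CCn1c(=S)n(C2OC(COCc3ccccc3)[C@H]3OC(C)(C)O[C@@H]23)c2nc(N)nc(O)c21`, gives 0%.

Both compounds were examined in a functional assay on the whole organism with Mus musculus as the target; a lower number here means a smaller maximal response, a higher number a larger maximal response. In this assay compound 1 reaches a maximal response of 5%, and compound 2 reaches 0%. The two numbers sit close to the floor of the measurement, and the gap between them lies within the usual scatter, so neither compound can be said to act more than the other; compound 1 simply stands together with compound 2 at the low end of what this assay reports.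

Compound 3, `Cn1c(=O)n(C2OC(CO)[C@@H](O)[C@H]2O)c2nc(N)nc(O)c21`, has not yet been tested. It differs from compound 1 by one change, (hydrogen in place of 2-phenylethenyl on a saturated chain carbon bound to an aromatic nitrogen). Going by the values given here, no pair of measured compounds differing in a single place is available, so there is no measured step to lean on. Since compound 1 gives 5% and compound 2 gives 0%, the expectation is that the step from compound 1 to compound 3 stays within the scatter, amounting to no change at the digits printed from compound 1 to compound 3 (within the scatter). Compound 3 is therefore estimated to reach 5% in this assay, within a range from 0% to 15%.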

Compound 3, largest response reached (reported as maximal response), in percent of the reference or control that the assay uses: 100%
Beside the measured number, compound 3's estimate is 95 percentage points below it; measured number outside the range, above it.
By their numbers in this assay, from the lowest: compounds 2 and 1 (each within the scatter of the next); then compound 3.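

In this assay, putting hydrogen in place of 2-phenylethenyl on a saturated chain carbon bound to an aromatic nitrogen gives a number 95 percentage points higher from compound 1 to compound 3 (beyond the scatter). Read one bond further out, this is 3-phenylprop-2-en-1-yl changed to methyl, and it shows that this position is far from silent and that the low number of compound 1 does not belong to the shared core alone: with methyl there, the core reaches a large maximal response. The compounds shown offer no measurement that explains a step of this size.

Going by these compounds, what stays open is how the response runs between the two groups compared here, since the series holds neither an ethyl group nor a benzyl group at this position, so a gradual fall cannot be told from a sudden one. On these data alone, compound 2, at 0%, differs from compound 3 in more than one place, so its number cannot be tied to any single change, and the separate contribution of each of its differences remains unknown.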